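A few compounds are considered here, and "the series" means these few. Any claim that something is new, unique, unknown or untested is made for them only; others in the source may bear on it.

Among the measured compounds shown here, in a functional assay on MCF7 cells (Homo sapiens) for antiproliferative activity, read by MTT assay, with stated times of 24 h and 72 h (on this read-out lower numbers stand for stronger inhibition and higher numbers for weaker inhibition), compound 1 (`COc1cc(N2C(=O)[C@@H](Oc3ccccc3)[C@H]2c2ccc(C#N)cc2)cc(OC)c1OC`) gives 31600 nM and compound 2 (`COc1cc(N2C(=O)[C@@H](Oc3ccccc3)[C@H]2c2cc(O)c(OC)c([N+](=O)[O-])c2)cc(OC)c1OC`) gives 69000 nM, the higher of the two numbers so far. For the measured compounds named here, the only measured step, a 2.2-fold higher number from compound 1 to compound 2 (0.34 log units; beyond the scatter), is modest and exchanges a whole group on a saturated ring carbon, so it bears only loosely on the next change. Compound 3 (`COc1cc(N2C(=O)[C@@H](Oc3ccccc3)[C@H]2c2cc(N)c(OC)c(O)c2)cc(OC)c1OC`) has amino in place of nitro on an aromatic carbon, ortho to a methoxy group and meta to a hydroxy group: amino in place of nitro on an aromatic carbon. Going by the values given here, no measured step covers this exchange. With so few data, the expectation in this assay is a lower number, by more than that modest step but with wide uncertainty. The estimated step is a 23-fold lower number from compound 2 to compound 3 (1.36 log units; beyond the scatter). For compound 3 the estimated value is 3000 nM, with an expected range of 100 nM to 40000 nM.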

Compound 3, half-maximal inhibitory concentration: 8800 nM
Compound 3: the middle estimate sits 2.9-fold (0.47 log units) below what was measured; the range from low to high includes it.
By their numbers in this assay, from the lowest: compound 3; then compound 1; then compound 2.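

Amino in place of nitro, on an aromatic carbon ortho to a methoxy group and meta to a hydroxy group, gives in this assay a 7.8-fold lower number from compound 2 to compound 3 (0.89 log units; beyond the scatter), so this single exchange moves the number beyond the scatter. The amino-bearing group on the saturated ring carbon also compares favourably with the nitrile-bearing group, with a 3.6-fold lower number from compound 1 to compound 3 (0.56 log units; beyond the scatter), whereas the nitro-bearing group gave a higher number than compound 1; compound 3 therefore has the lowest number of the three. Nothing at hand explains this shift.

Going by these compounds, whether a methylamino group, an acetamido group or a plain hydrogen at this aromatic carbon would lower the number further remains open. Also open, on these data alone, is whether the amino-for-nitro step holds without the neighbouring hydroxy and methoxy groups.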